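The source may report more compounds than this note shows. Statements on the series, on what has been measured and on what is new or still open speak of the compounds shown alone.

Measured in a functional assay on MCF7 cells (Homo sapiens) for cytotoxicity, read by MTT assay, with a stated time of 72 h; a lower number here means a stronger inhibitor, a higher number a weaker inhibitor:
- compound 1 `CCc1ccc(-c2cc(C(=O)Nc3ccc(Oc4ccnc(C(=O)NC)c4)cc3)ncn2)cc1`: 6350 nM
- compound 2 `CNC(=O)c1cc(Oc2ccc(NC(=O)c3nccc(-c4ccc([N+](=O)[O-])cc4)n3)cc2)ccn1`: > 100000 nM (a limit of the assay)
- compound 3 `CCc1ccc(-c2cc(C(=O)Nc3ccc(Oc4ccnc(C(=O)NC)c4)c(F)c3)ncn2)cc1`: 7630 nM

Compound 1 at 6350 nM has a single numeric neighbour, and a 1.2-fold higher number from compound 1 to compound 3 (0.08 log units; within the scatter). That step, fluoro in place of hydrogen, lies at a different place from the change now in question, so it bears only weakly. Compound 4 `CNC(=O)c1cc(Oc2ccc(NC(=O)c3cc(-c4ccc(F)cc4)ncn3)cc2)ccn1` differs from compound 1 as fluoro in place of ethyl on an aromatic carbon, that is, 4-ethylphenyl to 4-fluorophenyl. For the measured compounds named here, no measured step touches this group. Compound 2, which has no ethyl, reports only a limit of > 100000 nM, so a modest upward lean is expected in this assay. The estimated change is a 1.7-fold higher number from compound 1 to compound 4 (0.24 log units; within the scatter). For compound 4 the expected value is 11000 nM, with an estimated range of 4000 nM to 35000 nM.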

Compound 4, half-maximal inhibitory concentration: > 100000 nM
Compound 4 gave a limit, no number; the forecaster's own chance of this, stated with the estimate: 15%; middle value at least 9.0-fold (0.95 log units) from the limit.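

In this assay, for the compounds shown here, this position on the aryl ring is sensitive to the substituent: fluoro in place of ethyl gives an at least 15-fold higher number from compound 1 to compound 4 (1.19 log units; beyond the scatter), the first step beyond the scatter. Compound 4 gives > 100000 nM, which is a limit of the assay and not a number, so the step gives only a minimum size. Values at this limit cannot be ranked against each other: the limit of > 100000 nM in this assay, at which 2 of the 4 values shown sit.

As far as these compounds go, it remains open whether a longer chain such as propyl, a methoxy group or an amine at this place would hold the level of compound 1. From the compounds shown here alone, it is also open whether the step depends on removing ethyl or on introducing fluoro.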